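Shortening the Alkyl Tail of a Dimethoxyquinone

The source may report more compounds than this note shows. Statements on the series, on what has been measured and on what is new or still open speak of the compounds shown alone.

Compound 2 `CCCCCCCCCCCCCCCC1=C(C)C(=O)C(OC)=C(OC)C1=O` gives 94% in a functional assay on CCRF-CEM cells (Homo sapiens) for cytotoxicity, read by trypan blue exclusion, with stated times of 17 h and 6 h, tested at 5 uM (on this read-out higher numbers stand for a stronger effect at the one concentration tested and lower numbers for a weaker effect), the highest of the two numbers shown, with compound 1 `COC1=C(OC)C(=O)C(CCCCCCCCCCN=[N+]=[N-])=C(C)C1=O` nearest; in this assay compound 1 gives 92%. For the measured compounds named here, the one measured step, a number 2 percentage points higher from compound 1 to compound 2 (within the scatter), tells that exchanging the far end of the chain left the read-out essentially unchanged. Compound 3 `COC1=C(OC)C(=O)C(CCCCCCCCC(C)(C)C)=C(C)C1=O` differs from compound 2 by tert-butyl in place of heptyl on a saturated chain carbon, eight bonds along the chain from a double-bonded ring carbon, so the chain is cut back to a branched end while the shared core stays the same. Going by the values given here, only the step from compound 1 to compound 2 bears on this, and it lay within the scatter, so no step beyond the scatter is expected in this assay. Compound 3 is therefore estimated at 88%, with a range from 70% to 98%, which means an expected step of a number 6 percentage points lower from compound 2 to compound 3 (within the scatter).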

Compound 3, a percentage reported as activity, at one concentration (the size of the read-out at that concentration, not a potency): 93%
Estimate against measurement, compound 3: 5 percentage points below; the measured number falls inside the stated range.
By their numbers in this assay, from the lowest: compounds 1, 3 and 2 (each within the scatter of the next).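

In this assay compound 3 sits with the other two compounds, with a number 1 percentage points lower from compound 2 to compound 3 (within the scatter) and a number 1 percentage points higher from compound 1 to compound 3 (within the scatter) as its steps. This shows that at eight bonds along the chain from a double-bonded ring carbon, heptyl, with 7 heavy atoms, can give way to the branched tert-butyl, with 4 heavy atoms, without a step beyond the scatter. No measurement at hand accounts for this result.

From the compounds shown here alone, whether the read-out would hold with a much shorter tail, such as butyl, or with an amine or a carboxylic acid at the chain end remains open. Going by these compounds, all three compounds were compared at a single concentration, so whether their effects would be stronger or weaker relative to one another at any other concentration also remains open.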